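The source may report more compounds than this note shows. Statements on the series, on what has been measured and on what is new or still open speak of the compounds shown alone.

In a functional assay on HepG2 cells (Homo sapiens) for inhibition, read by MTT assay (on this read-out lower numbers stand for stronger inhibition and higher numbers for weaker inhibition), compound 1 (`COc1cc2ncnc(Nc3ccc(NC(=O)c4cccc(Cl)c4)cc3)c2cc1OC`) gives 12000 nM, while compound 2 (`COc1cc2ncnc(Nc3ccc(NC(=O)c4ccc(Br)cc4)cc3)c2cc1OC`) gives 35000 nM, the higher of the two numbers. Compound 3 (`COc1cc2ncnc(Nc3ccc(NC(=O)c4ccccc4I)cc3)c2cc1OC`) keeps the shared core and carries 2-iodophenyl in place of 4-bromophenyl on a carbonyl carbon. Going by the values given here, only one measured step bears on this change, a 2.9-fold higher number from compound 1 to compound 2 (0.46 log units; beyond the scatter), which put 4-bromophenyl in place of 3-chlorophenyl at the same place. Among the compounds with values here, no compound with a 2-iodophenyl group has a measured value yet, so the guidance is thin. Compound 2, at 35000 nM, sits at the high end of the two numbers, so a modest step of similar size towards a lower number is expected in this assay. The expected change is a 2.2-fold lower number from compound 2 to compound 3 (0.34 log units; beyond the scatter). For compound 3 the estimated value is 16000 nM, with an expected range from 6000 nM to 42000 nM.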

Compound 3, half-maximal inhibitory concentration: 33000 nM
Estimate against measurement, compound 3: 2.1-fold (0.31 log units) below; low and high end bracket the measured number.
By their numbers in this assay, from the lowest: compound 1; then compounds 3 and 2 (each within the scatter of the next).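

Replacing 4-bromophenyl with 2-iodophenyl on the carbonyl carbon leaves the number in this assay essentially unmoved (a 1.1-fold lower number from compound 2 to compound 3 (0.03 log units; within the scatter)), so these two different groups cannot be told apart here. A second group now also stands apart from the 3-chlorophenyl of compound 1 (a 2.8-fold higher number from compound 1 to compound 3 (0.44 log units; beyond the scatter)), much as the 4-bromophenyl did (a 2.9-fold higher number from compound 1 to compound 2 (0.46 log units; beyond the scatter)), and among these three compounds the 3-chlorophenyl alone gives the lowest number. No evidence at hand accounts for this result.

Each compound changes both the halogen and its printed position, so the compounds shown cannot separate the two, which a 3-bromophenyl or 3-iodophenyl group could begin to do. They also leave open how an unsubstituted phenyl, an aminophenyl or a carboxyphenyl group would read at this place.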